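Methylsulfanyl on the propoxy chain of compound 3

A few compounds are considered here, and "the series" means these few. Any claim that something is new, unique, unknown or untested is made for them only; others in the source may bear on it.

In a functional assay on a cell-free system (plasma, Homo sapiens) for inhibition, with Plasma (Rattus norvegicus) as the target (a lower number here means a stronger inhibitor, a higher number a weaker inhibitor), compound 1 (`O=c1cc(N2CCNCC2)c2ccccc2o1`) gives 49000 nM and compound 2 (`O=c1cc(N2CCNCC2)c2ccc(OCc3ccccc3)cc2o1`) gives 16300 nM as its number. Compound 3 (`CCCOc1ccc2c(N3CCNCC3)cc(=O)oc2c1C`) stands lowest of the three at 2950 nM so far. Compound 4 (`CSCCOc1ccc2c(N3CCNCC3)cc(=O)oc2c1C`) is unmeasured and carries one change from compound 3 (methylsulfanyl in place of methyl on a saturated chain carbon, two bonds along the chain from an oxygen on an aromatic ring) that turns propoxy into 2-(methylsulfanyl)ethoxy. Among the measured compounds shown here, the only measured step shows a 3.0-fold lower number from compound 1 to compound 2 (0.48 log units; beyond the scatter) with benzyloxy in place of hydrogen on an aromatic carbon, a modest change of another kind that bears only weakly here. For the measured compounds named here, no measured step touches the chain, so no step beyond the scatter is expected in this assay in either direction. The estimated change is a 1.0-fold higher number from compound 3 to compound 4 (0.01 log units; within the scatter) within the scatter. Compound 4 is estimated at 3000 nM within an expected range from 1200 nM to 7500 nM in this read-out.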

Compound 4, half-maximal inhibitory concentration: 1500 nM
Beside the measured number, compound 4's estimate is 2.0-fold (0.30 log units) above it, within the range that was stated.
By their numbers in this assay, from the lowest: compounds 4 and 3 (each within the scatter of the next); then compound 2; then compound 1.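

In this assay, among the compounds shown here, the only step on this chain reads a 2.0-fold lower number from compound 3 to compound 4 (0.29 log units; within the scatter). Methylsulfanyl in place of methyl on a saturated chain carbon is therefore accepted at this position, with no shift that can be separated from the scatter. The chain thus takes on a sulfur atom and one hydrogen-bond acceptor with the number still in the range of compound 3.

As far as these compounds go, whether a longer chain, a methoxy end group or a terminal amine would move the number beyond the scatter stays open. No data at hand account for the step.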